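A few compounds are considered here, and "the series" means these few. Any claim that something is new, unique, unknown or untested is made for them only; others in the source may bear on it.

The series keeps one core and varies the group on the ring nitrogen whose other neighbours are an aromatic carbon and a saturated chain carbon. Compound 1 `CN(C(=O)c1ccccc1)c1ccc2[nH]c(-c3n[nH]c4ccccc34)cc2n1` carries a benzoyl group there, and in a functional assay on HCT-116 cells (Homo sapiens) for antiproliferative activity, read by MTT assay, with a stated time of 72 h (on this read-out higher numbers stand for weaker inhibition and lower numbers for stronger inhibition), compound 1 gives 10600 nM. Compound 2 `CN(C(=O)c1ccc(Cl)cc1)c1ccc2[nH]c(-c3n[nH]c4ccccc34)cc2n1` carries a 4-chlorobenzoyl group, and in this assay compound 2 gives 3000 nM; the step of a 3.5-fold lower number from compound 1 to compound 2 (0.55 log units; beyond the scatter) is modest. Compound 3 `CN(C(=O)c1ccc(Br)cc1)c1ccc2[nH]c(-c3n[nH]c4ccccc34)cc2n1` carries a 4-bromobenzoyl group, and in this assay compound 3 gives 6110 nM. Compound 3 holds the second highest of the three numbers: the step of a 1.7-fold lower number from compound 1 to compound 3 (0.24 log units; within the scatter) stays within the scatter, while a 2.0-fold higher number from compound 2 to compound 3 (0.31 log units; beyond the scatter) is modest.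

Compound 4 `CN(c1ccc2[nH]c(-c3n[nH]c4ccccc34)cc2n1)S(=O)(=O)c1ccccc1` differs from compound 3 by phenylsulfonyl in place of (4-bromophenyl)carbonyl on a nitrogen on an aromatic ring. Among the compounds with values here, none of the measured steps exchanges a carbonyl for a sulfonyl; they only alter the halogen on an aromatic carbon. The nearest guidance is the pair compound 3 and compound 1, whose values show that removing the bromine stays within the scatter, so an unsubstituted phenyl carbonyl analogue would sit near the number of compound 1, 10600 nM. Within the data shown here, the carbonyl-to-sulfonyl exchange itself has no precedent, so the expected step of a 1.6-fold higher number from compound 3 to compound 4 (0.21 log units; within the scatter) is uncertain in direction and the range is kept wide. Compound 4 is estimated at 10000 nM in this assay, with a range of 2000 nM to 50000 nM.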

Compound 4, half-maximal inhibitory concentration: 6740 nM
Beside the measured number, compound 4's estimate is 1.5-fold (0.17 log units) above it, and the stated range covers the measured number.
By their numbers in this assay, from the lowest: compound 2; then compounds 3, 4 and 1 (each within the scatter of the next).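

In this assay a sulfonyl on the ring nitrogen reads much like a carbonyl there: the exchange for benzoyl, with the phenyl ring unchanged, gives a 1.6-fold lower number from compound 1 to compound 4 (0.20 log units; within the scatter) and the exchange for (4-bromophenyl)carbonyl gives a 1.1-fold higher number from compound 3 to compound 4 (0.04 log units; within the scatter) and both stay within the scatter, so at this position the carbonyl is not needed to hold the level of these compounds. Within the data shown here, the one step that leaves the scatter is a 2.2-fold higher number from compound 2 to compound 4 (0.35 log units; beyond the scatter) and it is modest, so the 4-chlorobenzoyl group remains the only one of the four whose number is set apart from all the others, and the sulfonyl exchange does not reach it. Nothing available explains why the carbonyl and sulfonyl forms read alike.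

The compounds shown leave open whether chloro on the phenylsulfonyl group would bring the same gain as a 3.5-fold lower number from compound 1 to compound 2 (0.55 log units; beyond the scatter) since halogen and sulfonyl are seen only apart. Also open, on these data alone, is how the position would respond to an acetyl group or a longer alkyl chain in place of the aromatic ring, or to a dimethylamino group or a carboxylic acid on that ring.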